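Compound 4: Imidazolyl Enters Two Bonds From Sulfur

This account rests on a few compounds, and the source may have more. Where it says the series, first, only, none or still open, it means among the compounds named here.

Compound 3 `CC(C)c1n[nH]c2c(NCc3ccc(-c4ccccn4)cc3)nc(SCCNC(=N)N)nc12` gives 390 nM in a functional assay on HT cells (Homo sapiens) for antiproliferative activity, read by fluorescence, with a stated time of 72 h (a higher number here means a weaker inhibitor of growth, a lower number a stronger inhibitor of growth), the second highest of three numbers: compound 1 `CC(C)c1n[nH]c2c(NCc3ccc(-c4ccccn4)cc3)nc(SCC(O)C(F)(F)F)nc12` gives 690 nM, and compound 2 `CC(C)c1n[nH]c2c(NCc3ccc(-c4ccccn4)cc3)nc(SCCCN(C)C)nc12` gives 105 nM. The step of a 1.8-fold lower number from compound 1 to compound 3 (0.25 log units; within the scatter) lies within the scatter, whereas the step of a 3.7-fold higher number from compound 2 to compound 3 (0.57 log units; beyond the scatter) lies beyond it. Compound 4 `CC(C)c1n[nH]c2c(NCc3ccc(-c4ccccn4)cc3)nc(SCCn3ccnc3)nc12` differs from compound 3 as follows: a group of 5 heavy atoms (3 carbon, 2 nitrogen; one five-membered aromatic ring with 2 hetero atoms) in place of a group of 4 heavy atoms (1 carbon, 3 nitrogen; no ring), on a saturated chain carbon, two bonds along the chain from a sulfur. Among the measured compounds shown here, the only measured step at the same place, two bonds along the chain from a sulfur, is a 3.7-fold higher number from compound 2 to compound 3 (0.57 log units; beyond the scatter), in which the group of 4 heavy atoms with 1 carbon and 3 nitrogen gave the higher number. For the measured compounds named here, for 1H-imidazol-1-yl at this place there is no measured precedent, and the uncertainty is wide. A modest lower number is nevertheless expected for compound 4: a 2.0-fold lower number from compound 3 to compound 4 (0.29 log units; within the scatter). Compound 4 is estimated at 200 nM, between 70 nM and 600 nM.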

Compound 4, concentration for 50% growth inhibition: 155 nM
Estimate against measurement, compound 4: 1.3-fold (0.11 log units) above, and the stated range covers the measured number.
By their numbers in this assay, from the lowest: compounds 2 and 4 (each within the scatter of the next); then compounds 3 and 1 (each within the scatter of the next).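

In this assay, 1H-imidazol-1-yl, the only ring among the groups shown at this place, two bonds along the chain from a sulfur, improves on the guanidine-type group of compound 3 (a 2.5-fold lower number from compound 3 to compound 4 (0.40 log units; beyond the scatter)) and stands level with (dimethylamino)methyl (a 1.5-fold higher number from compound 2 to compound 4 (0.17 log units; within the scatter)). So a ring with 0 hydrogen-bond donors is tolerated here, and it also keeps its distance from the group of compound 1 (a 4.5-fold lower number from compound 1 to compound 4 (0.65 log units; beyond the scatter)). Nothing measured here explains these steps. Open, from the compounds shown here alone, is whether a phenyl ring or a morpholine would serve equally well at this place. Going by these compounds, a longer chain carrying the imidazole also remains untested in these data.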